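Two chlorines for a trifluoromethyl on a cytotoxicity series

The compounds below may be only part of what the source reports. "The series", "measured", "known", "first", "only" and "open" are said of these compounds alone.

Measured compounds:
Compound 1, `CC(C)N(Cc1cccc(OCCCCCC(=O)O)c1)C(=O)c1ccc(-c2cccc3ccccc23)cc1`: > 26000 nM
Compound 2, `COc1cc(F)cc(-c2ccc(C(=O)N(Cc3cccc(OCCCCCC(=O)O)c3)C(C)C)cc2)c1`: > 26000 nM
Compound 3, `CC(C)N(Cc1cccc(OCCCCCC(=O)O)c1)C(=O)c1ccc(-c2cccc(C(F)(F)F)c2)cc1`: > 26000 nM

The three compounds were tested in an ADME assay on Raji cells (Homo sapiens) for cytotoxicity, read by CellTiter-Glo and resazurin assay, with a stated time of 72 h; a lower number here means that less compound is needed, a higher number that more compound is needed for the effect. Compound 3 returned only a limit, > 26000 nM. Compound 1 likewise gave only a limit, > 26000 nM. Compound 2 also gave only a limit, > 26000 nM. Every value shown therefore sits at the same place, as the limit of > 26000 nM in this assay, at which 3 of the 3 values shown sit, records, and none of the steps can be read: a step that the two limits leave unreadable from compound 1 to compound 2, a step that the two limits leave unreadable from compound 1 to compound 3, and a step that the two limits leave unreadable from compound 2 to compound 3.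

Compound 4, `CC(C)N(Cc1cccc(OCCCCCC(=O)O)c1)C(=O)c1ccc(-c2ccc(Cl)c(Cl)c2)cc1`, has not yet been measured in this assay. It differs from compound 3 in one place: 3,4-dichlorophenyl in place of 3-(trifluoromethyl)phenyl on an aromatic carbon. For the measured compounds named here, the only steps that bear on it are the three unreadable ones among compounds 1, 2 and 3, all of which end at the limit; no direction and no size can be taken from them.

Given that every compound measured so far sits at the limit, compound 4 is expected to do the same, and its value in this assay is estimated at 30000 nM, between 12000 nM and 100000 nM. The step this estimate means, a step that the limit leaves unreadable from compound 3 to compound 4, is expected to be none beyond the scatter.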

Compound 4, half-maximal effective concentration: > 26000 nM
Compound 4: no number, only a limit; the forecaster's own chance of this, stated with the estimate: 85%; the middle value is on the limit's open side.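

In this assay compound 4 gives > 26000 nM, again only a limit. The steps joining compound 4 to compounds 1, 2 and 3 therefore cannot be read, and all four compounds stand at the same place: the limit of > 26000 nM in this assay, at which 4 of the 4 values shown sit.

The compounds shown leave open how the four groups at this position compare, since none of the four has a numerical value.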